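The compounds below may be only part of what the source reports. "The series", "measured", "known", "first", "only" and "open" are said of these compounds alone.

In a functional assay on CHO cells for antagonist activity at C-C chemokine receptor type 4 (Homo sapiens), read by GTPgammaS binding (on this read-out higher numbers stand for weaker inhibition and lower numbers for stronger inhibition), compound 1 `CC(=O)NCc1cccc(Cn2nc(NS(=O)(=O)c3ccc(Cl)s3)c3ccccc32)c1` gives 251 nM, while compound 2 `CC(=O)NCc1cccc(Cn2nc(NS(=O)(=O)c3ccc(Cl)s3)c3c(CO)cccc32)c1` gives 6.31 nM, the lower of the two numbers, reached by a 40-fold lower number from compound 1 to compound 2 (1.60 log units; beyond the scatter). Compound 3 `CC(=O)NCc1cccc(Cn2nc(NS(=O)(=O)c3ccc(Cl)s3)c3c(C(C)O)cccc32)c1` carries methyl in place of hydrogen on a saturated chain carbon bound to an aromatic carbon and an oxygen on a saturated carbon. Going by the values given here, the single measured step concerns a different change, hydroxymethyl in place of hydrogen on an aromatic carbon, so nothing measured speaks directly to a methyl on the saturated carbon that bears the oxygen. Compound 3 is therefore expected to move little, an estimated 1.6-fold higher number from compound 2 to compound 3 (0.20 log units; within the scatter), if at all beyond the scatter. In this assay compound 3 is estimated at 10 nM, with a range from 3 nM to 40 nM.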

Compound 3, half-maximal inhibitory concentration: 20 nM
The estimate for compound 3 lay 2.0-fold (0.30 log units) below the measured number; measured number inside the range.
By their numbers in this assay, from the lowest: compound 2; then compound 3; then compound 1.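

In this assay, the saturated carbon bearing the oxygen is sensitive to added bulk, though only modestly: methyl in place of hydrogen there gives a 3.2-fold higher number from compound 2 to compound 3 (0.50 log units; beyond the scatter), so hydroxymethyl remains ahead of 1-hydroxyethyl. Much of the gain over hydrogen on the aromatic carbon survives this change, with a 13-fold lower number from compound 1 to compound 3 (1.10 log units; beyond the scatter). Nothing available explains the size of either step.

Still open, going by these compounds, is whether a longer chain on this carbon would cost more than methyl. Also open, on these data alone, is whether an amine in place of the hydroxyl would retain the gain.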